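Trimethoxyphenyl in Place of Methylphenyl at the Carbonyl

This account rests on a few compounds, and the source may have more. Where it says the series, first, only, none or still open, it means among the compounds named here.

Measured in a functional assay on HepG2 cells (Homo sapiens) for cytotoxicity, read by MTT assay, with a stated time of 48 h; on this read-out lower numbers stand for stronger inhibition and higher numbers for weaker inhibition:
compound 1, `COc1cc(-c2nnc3n2NC(c2ccco2)C(C(=O)c2ccc(Cl)cc2)S3)cc(OC)c1OC`, gives 78600 nM.
compound 2, `COc1cc(-c2nnc3n2NC(c2ccco2)C(C(=O)c2ccc(F)cc2)S3)cc(OC)c1OC`, reaches only a limit, > 100000 nM, that is the limit of > 100000 nM in this assay, at which 1 of the 3 values shown sits.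
compound 3, `COc1cc(-c2nnc3n2NC(c2cccs2)C(C(=O)c2ccc(C)cc2)S3)cc(OC)c1OC`, gives 3700 nM.

Compound 3 holds the lowest of the two numbers; compound 1 is its nearest neighbour and stands far higher, while compound 2 shows only a limit. Compound 4, `COc1cc(C(=O)C2Sc3nnc(-c4cc(OC)c(OC)c(OC)c4)n3NC2c2cccs2)cc(OC)c1OC`, arises from compound 3 by 3,4,5-trimethoxyphenyl in place of 4-methylphenyl on a carbonyl carbon. Going by the values given here, the one measured step, an at least 1.2-fold higher number from compound 1 to compound 2 (0.10 log units; that floor lies within the scatter), concerns an exchange of halogens and lies within the scatter, so no measured step bears on a change at the carbonyl. Compound 3 and compound 1 differ in two places at once, so their gap cannot be assigned to either. The step from compound 3 to compound 4 is therefore expected to be a 2.2-fold higher number from compound 3 to compound 4 (0.33 log units; beyond the scatter), with wide uncertainty in either direction. Compound 4 is expected to give about 8000 nM, between 2000 nM and 40000 nM.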

Compound 4, half-maximal inhibitory concentration: > 100000 nM
Compound 4 gave a limit, no number (the forecaster's own chance of this, stated with the estimate: 10%); middle value at least 12-fold (1.09 log units) away from the limit.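

Going by these compounds alone, this is the first measured step at the carbonyl: in this assay, 3,4,5-trimethoxyphenyl in place of 4-methylphenyl on a carbonyl carbon gives an at least 27-fold higher number from compound 3 to compound 4 (1.43 log units; beyond the scatter), so the read-out responds strongly to the group carried at this position. Compound 4 gives only a limit, not a number, so the step has a floor but no measured size: the limit of > 100000 nM in this assay, at which 2 of the 4 values shown sit.

Which of the methoxy groups accounts for the change stays open. So does how a 4-aminophenyl or a 4-carboxyphenyl group would read on the same carbonyl carbon.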